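The compounds below may be only part of what the source reports. "The series", "measured", "known", "first", "only" and "open" are said of these compounds alone.

Of the compounds shown here, three sharing one core have been measured in a functional assay on HL-60 cells (Homo sapiens) for antiproliferative activity, read by MTT assay, with a stated time of 72 h; on this read-out higher numbers stand for weaker inhibition and lower numbers for stronger inhibition. Compound 1 (`NC1=NC2(CCSCC2)N(OCCCOc2cccc(Cl)c2)C(N)=N1`) gives 260 nM, and compound 2 (`NC1=NC2(CCSCC2)N(OCCCOc2ccc(Br)cc2)C(N)=N1`) gives 350 nM. Compound 3 (`NC1=NC2(CCSCC2)N(OCCCOc2cc(Cl)c(Cl)cc2Cl)C(N)=N1`) gives 730 nM, the highest number of the three and so the weakest inhibition.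

Compound 4 (`NC1=NC2(CCSCC2)N(OCCCOc2ccc(Cl)cc2)C(N)=N1`) differs from compound 3 in one place: 4-chlorophenyl in place of 2,4,5-trichlorophenyl on an oxygen on a saturated carbon. In short, 4-chlorophenyl stands in place of 2,4,5-trichlorophenyl on an oxygen on a saturated carbon.

Going by the values given here, three measured steps bear on this change. Going to 2,4,5-trichlorophenyl gave a 2.1-fold higher number from compound 2 to compound 3 (0.32 log units; beyond the scatter) and a 2.8-fold higher number from compound 1 to compound 3 (0.45 log units; beyond the scatter), both modest. The step between the other two groups, a 1.3-fold higher number from compound 1 to compound 2 (0.13 log units; within the scatter), is small by comparison. Removing the 2,4,5-trichlorophenyl group is therefore expected to reverse a modest step, moving toward a lower number in this assay. The expected size is a 2.4-fold lower number from compound 3 to compound 4 (0.39 log units; beyond the scatter). For compound 4 the estimated value is 300 nM, with an expected range from 140 nM to 640 nM.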

Compound 4, half-maximal inhibitory concentration: 430 nM
Beside the measured number, compound 4's estimate is 1.4-fold (0.16 log units) below it; the range from low to high includes it.
By their numbers in this assay, from the lowest: compounds 1, 2, 4 and 3 (each within the scatter of the next, the first and the last beyond it).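

In this assay, the step from the 2,4,5-trichlorophenyl group to 4-chlorophenyl (a 1.7-fold lower number from compound 3 to compound 4 (0.23 log units; within the scatter)) lies within the scatter, although the same trichlorinated group stood beyond the scatter against both 3-chlorophenyl and 4-bromophenyl. Chloro in place of bromo on an aromatic carbon (a 1.2-fold higher number from compound 2 to compound 4 (0.09 log units; within the scatter)) and 4-chlorophenyl in place of 3-chlorophenyl (a 1.7-fold higher number from compound 1 to compound 4 (0.22 log units; within the scatter)) also stay within the scatter, so compound 4 cannot be told apart from any of the other three compounds. Nothing given here offers a reason for these steps.

The compounds shown leave open whether a phenyl group with no halogen, or one carrying a methoxy group or a carboxylic acid, would fall in the same range. They also leave open what a longer chain on the oxygen would do.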